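This account rests on a few compounds, and the source may have more. Where it says the series, first, only, none or still open, it means among the compounds named here.

Measured in an ADME assay on HEK293 cells (Homo sapiens) for cytotoxicity, read by MTT assay, with a stated time of 48 h; on this read-out higher numbers stand for weaker inhibition and lower numbers for stronger inhibition:
- compound 1 `Cn1c(N)c(-c2nc3ccccc3[nH]2)c2nc(C#N)c(C#N)nc21`: > 50000 nM (a limit)
- compound 2 `CCn1c(N)c(-c2nc3ccccc3[nH]2)c2nc(C#N)c(C#N)nc21`: > 50000 nM (a limit)
- compound 3 `N#Cc1nc2c(-c3nc4ccccc4[nH]3)c(N)n(CCN3CCCC3)c2nc1C#N`: 18300 nM

Compound 1 sits at the limit of > 50000 nM in this assay, at which 2 of the 3 values shown sit, and this is a limit of the assay, not a number. Compound 4 `CCN(CC)CCCCn1c(-c2c(N)n(C)c3nc(C#N)c(C#N)nc23)nc2ccccc21` keeps the core of compound 1 but places 4-(diethylamino)butyl in place of hydrogen on an aromatic nitrogen.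

Among the compounds with values here, no measured step makes this exact change, so the evidence is indirect. Lengthening the chain by methyl gave a step that the two limits leave unreadable from compound 1 to compound 2. Adding the pyrrolidine gave an at least 2.7-fold lower number from compound 1 to compound 3 (0.43 log units; beyond the scatter), and likewise an at least 2.7-fold lower number from compound 2 to compound 3 (0.43 log units; beyond the scatter). These two readable steps are the closest guide, although compound 3 carries its addition on a different aromatic nitrogen. With compound 3 at 18300 nM, a modest move towards a lower number, meaning stronger inhibition, in this assay is expected, and the step could prove larger or remain unreadable. The expected change is an at least 3.3-fold lower number from compound 1 to compound 4 (0.52 log units; beyond the scatter). The estimate for compound 4 is 15000 nM, with an expected range of 4000 nM to 50000 nM.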

Compound 4, half-maximal inhibitory concentration: 8820 nM
The estimate for compound 4 lay 1.7-fold (0.23 log units) above the measured number; the range from low to high includes it.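

In this assay, 4-(diethylamino)butyl in place of hydrogen on an aromatic nitrogen gives an at least 5.6-fold lower number from compound 1 to compound 4 (0.75 log units; beyond the scatter). Within the data shown here, the earlier steps all changed the chain on a different aromatic nitrogen, so this is the first sign that a group on this nitrogen of the five-membered ring can also lower the number. Compound 1 has only a limit here, not a number, so the step gives a minimum size and not an exact one: the limit of > 50000 nM in this assay, at which 2 of the 4 values shown sit.

The compounds shown cannot separate the part played by the butyl chain from that of the diethylamino group at its end. A plain butyl chain, or a butyl chain ending in a carboxylic acid, on this same nitrogen would be needed to tell them apart.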